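A few compounds are considered here, and "the series" means these few. Any claim that something is new, unique, unknown or untested is made for them only; others in the source may bear on it.

Measured in a functional assay on MDA-MB-231 cells (Homo sapiens) for antiproliferative activity, read by MTT assay, with a stated time of 72 h; a lower number here means a stronger inhibitor, a higher number a weaker inhibitor:
Compound 1 `NC1=NC2(CCSCC2)N(OCCCOc2cccc(Cl)c2Cl)C(N)=N1`: 1 nM
Compound 2 `NC1=NC2(CCSCC2)N(OCCCOc2cc(Cl)c(Cl)cc2Cl)C(N)=N1`: 110 nM

Compound 2 stands at the higher of the two numbers in this assay, the weaker end of this small set. The next change leads to compound 3 `NC1=NC2(CCSCC2)N(OCCCOc2ccccc2Br)C(N)=N1`: 2-bromophenyl in place of 2,4,5-trichlorophenyl on an oxygen on a saturated carbon. In words, 2-bromophenyl comes in place of 2,4,5-trichlorophenyl on an oxygen on a saturated carbon, with the shared core and chain untouched. Among the compounds with values here, one measured step bears on this, a 110-fold higher number from compound 1 to compound 2 (2.04 log units; beyond the scatter), a large change beyond the scatter that arose at this same place when the 2,4,5-trichlorophenyl group came in. Within the data shown here, with that group now leaving, a sizeable move back towards a lower number is expected, though no 2-bromophenyl compound has been measured, so the size remains uncertain. The expected change is a 9.2-fold lower number from compound 2 to compound 3 (0.96 log units; beyond the scatter). For compound 3 the estimated value is 12 nM, with an expected range of 1.5 nM to 100 nM.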

Compound 3, half-maximal inhibitory concentration: 10 nM
The estimate for compound 3 lay 1.2-fold (0.08 log units) above the measured number, within the range that was stated.
By their numbers in this assay, from the lowest: compound 1; then compound 3; then compound 2.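

In this assay, replacing 2,4,5-trichlorophenyl with 2-bromophenyl gives an 11-fold lower number from compound 2 to compound 3 (1.04 log units; beyond the scatter), which shows that the loss seen at this place can be partly recovered by changing the aryl group alone, with the shared core and chain untouched. The recovery is incomplete, since going from 2,3-dichlorophenyl to 2-bromophenyl gives a 10-fold higher number from compound 1 to compound 3 (1.00 log units; beyond the scatter), so the three aryl groups occupy three separate levels, with 2,3-dichlorophenyl still the lowest. Nothing available explains why these groups differ in this way.

The compounds shown leave open how an unsubstituted phenyl or a 2-chlorophenyl group would compare, and so whether the bromine itself matters to the number of compound 3. From the compounds shown here alone, it also remains open how this aryl series would respond to a longer chain on the oxygen or to an amine on the ring.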